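Swapping the Aryl Substituent for a Pyridin-3-yl Group

The source may report more compounds than this note shows. Statements on the series, on what has been measured and on what is new or still open speak of the compounds shown alone.

Measured so far:
compound 1 `N#Cc1ccc(-c2cnc3[nH]cc(-c4nnc(-c5ccc(F)cc5)o4)c(=O)c3c2)cc1` — 25.6%
compound 2 `CS(=O)(=O)c1ccc(-c2cnc3[nH]cc(-c4nnc(-c5ccc(F)cc5)o4)c(=O)c3c2)cc1` — 39.5%

In a functional assay on HCT-116 cells (Homo sapiens) for positive allosteric modulation, read by MTT assay, with stated times of 24 h and 48 h, tested at 2.5 uM (on this read-out higher numbers stand for more inhibition of growth at the one concentration tested and lower numbers for less inhibition of growth), compound 2 gives the higher of the two numbers; the step of a number 13.9 percentage points higher from compound 1 to compound 2 (beyond the scatter) is the only one known. Compound 3 `O=c1c(-c2nnc(-c3ccc(F)cc3)o2)c[nH]c2ncc(-c3cccnc3)cc12` changes the same position again: pyridin-3-yl in place of 4-(methylsulfonyl)phenyl on an aromatic carbon. Among the measured compounds shown here, no measured step covers a group of this kind, so only the modest step from cyano to methylsulfonyl gives a sense of scale. The step of a number 9.5 percentage points lower from compound 2 to compound 3 (within the scatter) is therefore expected to stay within the scatter. Compound 3 is estimated at 30%, in the range 15% to 45%.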

Compound 3, percent growth inhibition at one concentration: 20.1%
The estimate for compound 3 lay 9.9 percentage points above the measured number, and the stated range covers the measured number.
By their numbers in this assay, from the lowest: compounds 3 and 1 (each within the scatter of the next); then compound 2.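

In this assay, the step of a number 19.4 percentage points lower from compound 2 to compound 3 (beyond the scatter) shows that the number at this position can drop when 4-(methylsulfonyl)phenyl gives way to pyridin-3-yl. The step of a number 5.5 percentage points lower from compound 1 to compound 3 (within the scatter) leaves compound 3 level with compound 1, so among these three groups only 4-(methylsulfonyl)phenyl stands apart. Nothing available explains why this group differs from the other two.

Whether the methylsulfonyl group itself accounts for this remains open. Also open, on these data alone, is how a plain phenyl ring, or a phenyl ring carrying an amine or a carboxylic acid, would read at this position.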